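The source may hold more compounds than are shown below. What is called first, only, known or untested is meant among the compounds shown, and "the series" means these compounds.

Measured compounds:
- Compound 1, `COc1ccccc1/C(N)=N/O`: > 800000 nM
- Compound 2, `Cc1cccc(C(=O)NO)c1`: 340000 nM
- Compound 3, `COc1cccc(C(=O)NO)c1`: 570000 nM

In an ADME assay on Huh-7 cells (Homo sapiens) for cytotoxicity, read by MTT assay, with a stated time of 72 h (on this read-out higher numbers stand for lower toxicity in this test and lower numbers for higher toxicity in this test), compound 1 shows only a limit, (the limit of > 800000 nM in this assay, at which 1 of the 3 values shown sits), not a number. Compound 2 and compound 3 sit within the scatter of each other, the change being a 1.7-fold higher number from compound 2 to compound 3 (0.22 log units; within the scatter). Compound 4, `O=C(NO)c1cccc(Cl)c1`, differs from compound 3 by chloro in place of methoxy on an aromatic carbon. For the measured compounds named here, no measured step swaps chloro for methoxy, so the only guide is that the one step on this ring, methoxy in place of methyl, stayed within the scatter. The expectation for compound 4 is therefore a step of a 1.1-fold lower number from compound 3 to compound 4 (0.06 log units; within the scatter), not beyond the scatter. Compound 4 is estimated at 500000 nM, between 200000 nM and 1000000 nM.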

Compound 4, half-maximal cytotoxic concentration: 120000 nM
Compound 4: middle estimate off by 4.2-fold (0.62 log units), on the high side, outside the stated range (below it).
By their numbers in this assay, from the lowest: compound 4; then compounds 2 and 3 (each within the scatter of the next). At a limit, above all of these: compound 1.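

On this ring, the group at this place does change the result in this assay. Chloro in place of methoxy gives a 4.8-fold lower number from compound 3 to compound 4 (0.68 log units; beyond the scatter), and chloro in place of methyl gives a 2.8-fold lower number from compound 2 to compound 4 (0.45 log units; beyond the scatter), so compound 4 reads as the more toxic in this test, whereas the earlier swap of methyl for methoxy stayed within the scatter. Nothing available here accounts for this difference.

The compounds shown leave open how a bromo group, an amine or a carboxylic acid at this same place would read. They also leave open whether the step seen with chloro would hold on another core.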